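This account rests on a few compounds, and the source may have more. Where it says the series, first, only, none or still open, it means among the compounds named here.

In a functional assay on RPMI-8226 cells (Homo sapiens) for cytotoxicity, read by MTT assay, with a stated time of 72 h (a higher number here means a weaker inhibitor, a lower number a stronger inhibitor), compound 1 (`Cc1c(C)c2c(c(C)c1OC(=O)CCC(=O)O)CCC(C)(C(=O)NCC1CC(C)(C)N([O])C1(C)C)O2`) gives > 300000 nM, which is a limit of the assay and not a number. Compound 2 (`Cc1c(C)c2c(c(C)c1O)CCC(C)(C(=O)NCC1CC(C)(C)N([O])C1(C)C)O2`), with hydrogen in place of (2-carboxyethyl)carbonyl on an oxygen on an aromatic ring, gives 70000 nM. Going by the values given here, that change is an at least 4.2-fold lower number from compound 1 to compound 2 (0.63 log units; beyond the scatter), a step beyond the scatter and the only measured step available here. Compound 3 (`Cc1c(C)c2c(c(C)c1OC(=O)CCC(=O)O)CCC(C)(C(=O)NC1CC(C)(C)N([O])C1(C)C)O2`) keeps the (2-carboxyethyl)carbonyl and differs from compound 1 at another place: a group of 10 heavy atoms (8 carbon, 1 nitrogen, 1 oxygen; one five-membered non-aromatic ring with 1 hetero atom) in place of a group of 11 heavy atoms (9 carbon, 1 nitrogen, 1 oxygen; one five-membered non-aromatic ring with 1 hetero atom), on an amide-type nitrogen. Among the compounds with values here, no measured step touches that amide-type nitrogen, so the step to compound 2 bears on this change only indirectly, and its size cannot be carried over. Compound 3 retains the group whose removal produced that step, so the limit that compound 1 shows at > 300000 nM is the nearest guide, and no step beyond the scatter is expected in this assay. The expected step is a number no higher from compound 1 to compound 3 (the limit leaves the size open), and another reading at the limit would be no surprise. Compound 3 is expected at 300000 nM, with an estimated range from 120000 nM to 700000 nM.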

Compound 3, half-maximal inhibitory concentration: > 300000 nM
Compound 3: only a limit was reported (the forecaster's own chance of this, stated with the estimate: 70%); the middle value sits exactly at the limit.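

In this assay compound 3 gives > 300000 nM, which is a limit of the assay and not a number. No step can be read between compound 1 and compound 3, because both stand at the same limit: the limit of > 300000 nM in this assay, at which 2 of the 3 values shown sit. The compounds shown leave open what the change on the amide-type nitrogen does to the value, since neither compound gives a number there.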